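A few compounds are considered here, and "the series" means these few. Any claim that something is new, unique, unknown or untested is made for them only; others in the source may bear on it.

Compound 1 is `O=Cc1c(O)cc(O)cc1/C=C/c1ccc(O)cc1`. In a functional assay on MDA-MB-435 cells (Homo sapiens) for cytotoxicity, read by MTT assay, with a stated time of 72 h (on this read-out higher numbers stand for weaker inhibition and lower numbers for stronger inhibition), compound 1 gives < 50000 nM, which is a limit of the assay and not a number. Compound 2 is `O=Cc1cc(/C=C/c2cc(O)cc(O)c2C=O)ccc1O`. In this assay compound 2 gives < 50000 nM, again a limit and not a number.

Compound 2 therefore stands only at the limit of < 50000 nM in this assay, at which 2 of the 2 values shown sit, and no number places it more exactly. Within the data shown here, the single measured step is a step that the two limits leave unreadable from compound 1 to compound 2, which the two limits leave without a readable size.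

Compound 3 is `O=Cc1cc(/C=C/c2cc(O)cc(O)c2)ccc1O`. It differs from compound 2 by hydrogen in place of formyl on an aromatic carbon. Among the measured compounds shown here, this is the reverse kind of change to the one measured step, and that step gives no size or direction to carry over. The expected step is therefore a step that the limit leaves unreadable from compound 2 to compound 3, with no direction that the measured values support. Compound 3 is estimated to give 20000 nM, within 3000 nM to 60000 nM, in this assay.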

Compound 3, half-maximal inhibitory concentration: < 50000 nM
Compound 3: only a limit was reported; the forecaster's own chance of this, stated with the estimate: 60%; the middle value does not contradict the limit.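

No size or direction can be read for the change from compound 2 to compound 3, because every result shown is a limit and not a number: the limit of < 50000 nM in this assay, at which 3 of the 3 values shown sit.

The compounds shown leave open how strongly compound 1, compound 2 and compound 3 each act in this assay, and whether the formyl matters at all.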